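This account rests on a few compounds, and the source may have more. Where it says the series, first, only, none or still open, it means among the compounds named here.

Three analogues sharing one core have been examined in an ADME assay on BCBL1 cells (Homo sapiens) for cytotoxicity, with a stated time of 7 days; a higher number here means that more compound is tolerated, a lower number that less compound is tolerated. Compound 1 `Nc1nc(NC2CC2)c2ncn(/C=C3/CC3(CO)CO)c2n1` carries a cyclopropylamino group on an aromatic carbon, and in this assay compound 1 gives 71500 nM. Compound 2 `Nc1nc(N2CCCC2)c2ncn(/C=C3/CC3(CO)CO)c2n1` has a pyrrolidin-1-yl group in that place. For compound 2 the result in this assay is only a limit, > 20000 nM. Compound 3 `CSc1nc(N)nc2c1ncn2/C=C1/CC1(CO)CO` has a methylsulfanyl group there. For compound 3 as well, this assay reports only a limit, > 20000 nM. Because two of the three results sit at a limit (the limit of > 20000 nM in this assay, at which 2 of the 3 values shown sit), none of the steps among these compounds can be sized: a step that the limit leaves unreadable from compound 1 to compound 2, a step that the limit leaves unreadable from compound 1 to compound 3 and a step that the two limits leave unreadable from compound 2 to compound 3 all remain unreadable. Compound 3 thus stands among the compounds for which only a limit, not a number, is available.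

Compound 4 `CC(C)Sc1nc(N)nc2c1ncn2/C=C1/CC1(CO)CO` differs from compound 3 in one place: isopropyl in place of methyl on a sulfur. Among the compounds with values here, no measured step bears directly on that change, and the three steps that exist are unreadable, so neither a size nor a direction can be drawn from them. The step that the limit leaves unreadable from compound 3 to compound 4 is therefore expected to stay within the scatter. In this assay compound 4 is expected to give about 60000 nM, between 20000 nM and 200000 nM, with a fair chance that only a limit is reported again.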

Compound 4, half-maximal cytotoxic concentration: > 20000 nM
Compound 4 was reported as a limit (the forecaster's own chance of this, stated with the estimate: 65%); the middle value lies beyond the limit too.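

In this assay compound 4 gives > 20000 nM as a limit, not a number. Its steps to compound 1, compound 2 and compound 3 cannot be read, because most results sit at one limit: the limit of > 20000 nM in this assay, at which 3 of the 4 values shown sit. The compounds shown leave open whether isopropyl in place of methyl on the sulfur changes the tolerated concentration at all, and by how much.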